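The compounds below may be only part of what the source reports. "The series", "measured", "known", "first", "only" and "open" are said of these compounds alone.

Measured compounds in this series:

- Compound 1 `Cc1ccccc1-c1nn(-c2ccc(OC(F)(F)F)cc2)cc1CNCCN1CCN(C)CC1`: in an ADME assay on Huh-7 cells (Homo sapiens) for cytotoxicity (on this read-out higher numbers stand for lower toxicity in this test and lower numbers for higher toxicity in this test), compound 1 gives 17000 nM.
- Compound 2 `Cc1ccccc1-c1nn(Cc2ccc(F)cc2)cc1CNCCN1CCN(C)CC1`: in this assay compound 2 gives > 20000 nM, which is a limit of the assay and not a number.
- Compound 3 `Cc1ccccc1-c1nn(-c2ccc(F)c(F)c2)cc1CNCCN1CCN(C)CC1`: in this assay compound 3 gives > 20000 nM, again a limit of the assay.

Compound 3 therefore stands at the ceiling of the readable range; compound 1 is the only one of the three with a number. The step of an at least 1.1-fold higher number from compound 1 to compound 3 (0.07 log units; that floor lies within the scatter) has a floor that lies within the scatter, and the step that the two limits leave unreadable from compound 2 to compound 3 cannot be read at all, since both ends are limits (the limit of > 20000 nM in this assay, at which 2 of the 3 values shown sit).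

Compound 4 `Cc1ccc(-n2cc(CNCCN3CCN(C)CC3)c(-c3ccccc3C)n2)c(C)c1` differs from compound 3 in one place: 2,4-dimethylphenyl in place of 3,4-difluorophenyl on an aromatic nitrogen. Going by the values given here, no measured step shows what a change of this kind does here; the two steps that end at compound 3 give only a floor within the scatter or nothing readable. The expectation for compound 4 is that this assay again returns a value at or near the limit, with the step of a number no higher from compound 3 to compound 4 (the limit leaves the size open) expected to lie within the scatter. The estimated value for compound 4 is 20000 nM, with a range from 8000 nM to 50000 nM.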

Compound 4, half-maximal cytotoxic concentration: > 20000 nM
Compound 4 was reported as a limit; the forecaster's own chance of this, stated with the estimate: 60%; the middle value lies on the limit itself.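

Going by these compounds alone, compound 4 is the first in this set whose group on the aromatic nitrogen holds carbon only, and in this assay it too sits at a limit of the assay, so fluorine in that group is not required for a value at the limit. The only readable step to compound 4 is an at least 1.1-fold higher number from compound 1 to compound 4 (0.07 log units; that floor lies within the scatter), so no difference beyond the scatter is shown, and the steps between compound 4 and compounds 2 and 3 cannot be read, since both ends are limits. The series now gathers at one end of the readable range: the limit of > 20000 nM in this assay, at which 3 of the 4 values shown sit.

The compounds shown leave open whether any group on this aromatic nitrogen gives a value clearly lower than that of compound 1, the only compound with a number, at 17000 nM. A phenyl ring carrying an amine or a carboxylic acid, or a longer chain in place of 4-fluorobenzyl, would test whether the read-out moves away from the limit at this position.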